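Fluoro in place of methoxy: notes on the series

This account rests on a few compounds, and the source may have more. Where it says the series, first, only, none or still open, it means among the compounds named here.

In a functional assay on SK-MEL-28 cells (Homo sapiens) for inhibition, read by colorimetric assay and MTT assay, with a stated time of 72 h (a higher number here means a weaker inhibitor, a lower number a stronger inhibitor), compound 1 `Cc1ccc2c(c1)-c1cnc(n1C)OCCCCCCCCO2` gives 55000 nM, and compound 2 `COc1ccc2c(c1)-c1cnc(n1C)OCCCCCCCCO2` gives 57000 nM. For the measured compounds named here, these are the only two measurements so far, and they lie within the scatter of each other, so compound 2 stands level with compound 1.

Compound 3 `Cn1c2cnc1OCCCCCCCCOc1ccc(F)cc1-2` remains unmeasured. It departs from compound 2 by fluoro in place of methoxy on an aromatic carbon.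

Going by the values given here, one measured step bears on this change: a 1.0-fold higher number from compound 1 to compound 2 (0.02 log units; within the scatter), with methoxy in place of methyl on an aromatic carbon. That step lies within the scatter. Among the compounds with values here, it is only indirect evidence, as neither measured compound carries fluoro, and no measured step leads to or from that group. On this evidence, no step beyond the scatter is expected in this assay, and neither direction is favoured.

The estimated step is a 1.0-fold lower number from compound 2 to compound 3 (0.02 log units; within the scatter), and it is expected to remain within the scatter. For compound 3 the estimate is 55000 nM, with an expected range of 25000 nM to 110000 nM.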

Compound 3, half-maximal inhibitory concentration: 72000 nM
Estimate against measurement, compound 3: 1.3-fold (0.12 log units) below, and the stated range covers the measured number.
By their numbers in this assay, from the lowest: compounds 1, 2 and 3 (each within the scatter of the next).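

In this assay, for the compounds shown here, fluoro gives the first reading of a halogen on this aromatic carbon, and it gives no step beyond the scatter: a 1.3-fold higher number from compound 2 to compound 3 (0.10 log units; within the scatter), and a 1.3-fold higher number from compound 1 to compound 3 (0.12 log units; within the scatter). Methyl, methoxy and fluoro therefore stand level here, and the measured numbers do not separate them. Replacing the two heavy atoms and one hydrogen-bond acceptor of methoxy with the single heavy atom of fluoro leaves the number within the scatter, and no measurement at hand offers an explanation for this result.

The compounds shown leave open whether any group on this carbon can move the number beyond the scatter, for example an amine or a carboxylic acid. They also leave open how much the number depends on the chain shared by compounds 1, 2 and 3, as all three carry the same chain and a shorter or longer chain would be needed to test this.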